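Coumarin pyrazoline series: acyl exchange on the ring nitrogen

The source may report more compounds than this note shows. Statements on the series, on what has been measured and on what is new or still open speak of the compounds shown alone.

Measured so far:
compound 1, `CC1=NN(S(=O)(=O)c2ccc([N+](=O)[O-])cc2)C(c2cc(Cl)ccc2O)C1` — "not active" (no number reported) in a functional assay on HepG2 cells (Homo sapiens) for cytotoxicity, read by MTT assay, with a stated time of 48 h; a higher number here means a weaker inhibitor, a lower number a stronger inhibitor
compound 2, `CC(=O)Oc1ccccc1C1CC(C)=NN1C(=O)CN1CCC(C(C)=O)CC1` — 7800 nM
compound 3, `O=C(c1ccccc1)N1N=C(c2cc3ccccc3oc2=O)CC1c1ccccc1` — 36600 nM

Compound 3 stands highest of the two numbers. Compound 2 sits a good deal lower, and that gap lies beyond the scatter; compound 1 gave no number. Compound 3 and compound 2 differ in more than one place, so their two values alone carry the comparison.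

Compound 4, `CC1CCCN(CC(=O)N2N=C(c3cc4ccccc4oc3=O)CC2c2ccccc2)C1`, is not yet measured. It differs from compound 3 as follows: (3-methylpiperidin-1-yl)methyl in place of phenyl on a carbonyl carbon. Compound 2 likewise carries a cyclic amine on its acyl group and gives 7800 nM, so the step of a 2.0-fold lower number from compound 3 to compound 4 (0.31 log units; beyond the scatter) is expected to run downward by a moderate amount. Compound 4 is estimated at 18000 nM, with a range from 6000 nM to 55000 nM.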

Compound 4, half-maximal inhibitory concentration: "not active" (no number reported)
No number was reported for compound 4; there is nothing to compare the estimate with.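

In this assay, among the compounds shown here, compound 4 gives "not active" (no number reported) and no step from compound 3 can be read. On these data alone, what the exchange of benzoyl for ((3-methylpiperidin-1-yl)methyl)carbonyl does on the shared core stays open. No measured evidence bears on this result.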